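This account rests on a few compounds, and the source may have more. Where it says the series, first, only, none or still open, it means among the compounds named here.

In a functional assay on CCRF-CEM cells (Homo sapiens) for cytotoxicity, read by XTT assay, with a stated time of 3 days (a lower number here means a stronger inhibitor, a higher number a weaker inhibitor), the measured compounds are:
- compound 1 `OC[C@H]1O[C@@H](n2cc(F)c3c(-c4ccco4)ncnc32)[C@H](O)[C@@H]1O`: 1400 nM
- compound 2 `OC[C@H]1O[C@@H](n2cc(F)c3c(-c4nccs4)ncnc32)[C@H](O)[C@@H]1O`: 550 nM
- compound 3 `OC[C@H]1O[C@@H](n2cc(Cl)c3c(-c4ccco4)ncnc32)[C@H](O)[C@@H]1O`: 3800 nM

Of these three, compound 3 has the highest number, 3800 nM, and so is the weakest inhibitor. Compound 4 `OC[C@H]1O[C@@H](n2cc(Cl)c3c(-c4ccsc4)ncnc32)[C@H](O)[C@@H]1O` has not yet been measured. It differs from compound 3 in one place, with thiophen-3-yl in place of furan-2-yl on an aromatic carbon.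

The closest measured change is a 2.5-fold lower number from compound 1 to compound 2 (0.41 log units; beyond the scatter), where furan-2-yl also leaves, though 1,3-thiazol-2-yl enters. The other measured change, a 2.7-fold higher number from compound 1 to compound 3 (0.43 log units; beyond the scatter), is chloro in place of fluoro and leaves furan-2-yl untouched, so it only shows how compound 3 reached its value. Among the measured compounds shown here, no measured compound carries thiophen-3-yl, so the direction remains uncertain. A modest step toward a lower number is expected, similar in size to a 2.5-fold lower number from compound 1 to compound 2 (0.41 log units; beyond the scatter). The estimated change is a 2.2-fold lower number from compound 3 to compound 4 (0.35 log units; beyond the scatter). For compound 4, the estimate is 1700 nM, with an expected range of 500 nM to 5500 nM.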

Compound 4, half-maximal inhibitory concentration: 1000 nM
Compound 4: the middle estimate sits 1.7-fold (0.23 log units) above what was measured; the range from low to high includes it.
By their numbers in this assay, from the lowest: compounds 2, 4 and 1 (each within the scatter of the next, the first and the last beyond it); then compound 3.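

In this assay, with chloro held fixed, thiophen-3-yl in place of furan-2-yl on the aromatic carbon of the six-membered aromatic ring gives a 3.8-fold lower number from compound 3 to compound 4 (0.58 log units; beyond the scatter), so this position responds even when one five-membered aromatic ring with 1 hetero atom replaces another of the same heavy-atom count. The earlier change at this position, a 2.5-fold lower number from compound 1 to compound 2 (0.41 log units; beyond the scatter), had fluoro on the core and brought in 1,3-thiazol-2-yl; the new step shows that a lower number on leaving furan-2-yl also occurs with chloro and with a different incoming ring. Nothing available here bears on why the number falls.

The compounds shown leave open whether thiophen-3-yl would also lower the number with fluoro in place of chloro, and how 1,3-thiazol-2-yl would behave with chloro. They also leave open how thiophen-2-yl, a phenyl ring or an amine would compare at this same position.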